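A few compounds are considered here, and "the series" means these few. Any claim that something is new, unique, unknown or untested is made for them only; others in the source may bear on it.

Measured compounds:
compound 1, `COc1ccc(-c2nc(C)c(C(=O)CSc3nc(N)c(C#N)c(-c4ccc(Cl)cc4)n3)s2)cc1`, 4540 nM;
compound 2, `COc1ccc(-c2nc(C)c(C(=O)CSc3nc(N)c(C#N)c(-c4ccccc4)n3)s2)cc1`, 8540 nM;
compound 3, `Cc1nc(-c2ccc(Cl)cc2)sc1C(=O)CSc1nc(-c2ccc(Cl)c(Cl)c2)c(C#N)c(=O)[nH]1`, 83900 nM.

All three were tested in a functional assay on U-87MG ATCC cells for antiproliferative activity against U-87 MG (Homo sapiens), read by MTT assay, with a stated time of 48 h; on this read-out lower numbers stand for stronger inhibition and higher numbers for weaker inhibition. Compound 1 and compound 2 differ by one change, (hydrogen in place of chloro on an aromatic carbon), and that change made a step of a 1.9-fold higher number from compound 1 to compound 2 (0.27 log units; within the scatter). Compound 3 belongs to a different core; how its core differs from that of compound 1 is not broken down here. Its value stands beyond the scatter above both other compounds.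

Compound 4, `Cc1nc(-c2ccccc2)sc1C(=O)CSc1nc(-c2ccc(Cl)c(Cl)c2)c(C#N)c(=O)[nH]1`, has not yet been measured. It differs from compound 3 by hydrogen in place of chloro on an aromatic carbon, the same change that separates compound 1 from compound 2. Because that change gave a 1.9-fold higher number from compound 1 to compound 2 (0.27 log units; within the scatter), a step of similar size, a 1.7-fold higher number from compound 3 to compound 4 (0.22 log units; within the scatter), is expected from compound 3 to compound 4, resting on that single earlier pair. Compound 4 is therefore estimated at 140000 nM, with the range 60000 nM to 350000 nM.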

Compound 4, half-maximal inhibitory concentration: 65000 nM
Compound 4: middle estimate off by 2.2-fold (0.33 log units), on the high side; measured number inside the range.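

Replacing 4-chlorophenyl with phenyl on the core of compound 3 gave a step of a 1.3-fold lower number from compound 3 to compound 4 (0.11 log units; within the scatter). Set beside the earlier pair, the two steps do not differ by more than normal measurement noise: the same change on two cores in this assay, a 1.9-fold higher number (0.27 log units; within the scatter) from compound 1 to compound 2 and a 1.3-fold lower number (0.11 log units; within the scatter) from compound 3 to compound 4, 2.4-fold (0.39 log units) apart, within the scatter of two such steps. This suggests that the change can be carried between these two cores with little effect on the number, but two small steps cannot show whether it has any real effect, or in which direction, on either core.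

Still open, on these data alone, is whether another group at that same place, such as a fluoro, an amine or a carboxylic acid, would give a step beyond the scatter. It is also unknown whether this swap would behave the same way on further cores.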